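Cytotoxicity notes: hydroxy for amino on the shared core

The compounds below may be only part of what the source reports. "The series", "measured", "known", "first", "only" and "open" are said of these compounds alone.

Measured compounds and values in a functional assay on Vero cells (Chlorocebus sabaeus) for cytotoxicity; on this read-out lower numbers stand for stronger inhibition and higher numbers for weaker inhibition:
compound 1 `Nc1ccn([C@@H]2CC(F)(F)[C@H](CO)O2)c(=O)n1`: > 100000 nM, a limit of the assay.
compound 2 `Nc1ccn([C@H]2CC(F)(F)[C@H](CO)O2)c(=O)n1`: > 100000 nM, a limit of the assay.
compound 3 `Nc1nc(=O)n([C@@H]2CC(F)(F)[C@H](CO)O2)cc1F`: > 100000 nM, a limit of the assay.

Compound 1 stands at the limit, not at a number, and so do the two neighbours shown. The step that the two limits leave unreadable from compound 1 to compound 2 and the step that the two limits leave unreadable from compound 1 to compound 3 therefore cannot be sized; the two limits leave them unreadable, as the limit of > 100000 nM in this assay, at which 3 of the 3 values shown sit, makes clear.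

The unmeasured compound 4 `O=c1nc(O)ccn1[C@@H]1CC(F)(F)[C@H](CO)O1` differs from compound 1 by hydroxy in place of amino on an aromatic carbon. Within the data shown here, no measured step touches this position, and neither of the two readable-in-structure steps gives a number to carry over, since each ends at the same limit. Among the measured compounds shown here, the only guidance is that every change so far on this core, a change of configuration as drawn (the fact that compounds 1 and 2 differ only in the configuration as drawn) and fluoro in place of hydrogen on an aromatic carbon, left the read-out at the limit.

The expectation for compound 4 is therefore that this assay again reports no number, the step of a number no higher from compound 1 to compound 4 (the limit leaves the size open) being expected to lie within the scatter. Compound 4 is estimated at 100000 nM, with a range from 30000 nM to 300000 nM.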

Compound 4, half-maximal inhibitory concentration: > 100000 nM
Compound 4: a limit, no number; the forecaster's own chance of this, stated with the estimate: 85%; the middle value sits exactly at the limit.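

In this assay compound 4 gives > 100000 nM, which is a limit of the assay and not a number. Compound 1 also stands at a limit, so no new step can be read between compound 1 and compound 4. The compounds shown leave open what cytotoxicity value, if any, this shared core would reach, and so how much any of these changes matters: the limit of > 100000 nM in this assay, at which 4 of the 4 values shown sit.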